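The source may report more compounds than this note shows. Statements on the series, on what has been measured and on what is new or still open speak of the compounds shown alone.

The measured compounds:
compound 1, `COc1ccc(NC(=O)C2(C(=O)Nc3ccc(Nc4ncc5cc(C(=O)N(C)C)n(C6CCCC6)c5n4)cc3)CC2)cc1`, gives 78.5% in a functional assay on A549 cells (Homo sapiens) for inhibition, read by CCK-8 assay, with a stated time of 72 h, tested at 10 uM; a higher number here means more inhibition of growth at the concentration tested, a lower number less inhibition of growth.
compound 2, `CN(C)C(=O)c1cc2cnc(Nc3ccc(NC(=O)C4(C(=O)Nc5cccc(C#N)c5)CC4)cc3)nc2n1C1CCCC1`, gives 73.6%.
compound 3, `CN(C)C(=O)c1cc2cnc(Nc3ccc(NC(=O)C4(C(=O)Nc5cccc(C(F)(F)F)c5)CC4)cc3)nc2n1C1CCCC1`, gives 89.2%.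

Among these three, compound 1 stands second highest. Its nearest neighbour is compound 2, since a number 4.9 percentage points lower from compound 1 to compound 2 (within the scatter), a difference too small to count as real. Its furthest is compound 3, since a number 10.7 percentage points higher from compound 1 to compound 3 (beyond the scatter).

Compound 4, `CN(C)C(=O)c1cc2cnc(Nc3ccc(NC(=O)C4(C(=O)Nc5cccc(Br)c5)CC4)cc3)nc2n1C1CCCC1`, has not yet been tested in this assay. It differs from compound 1 in one place: 3-bromophenyl in place of 4-methoxyphenyl on an amide-type nitrogen. For the measured compounds named here, two measured steps bear on this. Each of them also swaps the 4-methoxyphenyl of compound 1 for a different phenyl group on the same amide-type nitrogen: the step to compound 2 brought a 3-cyanophenyl and went down within the scatter, the step to compound 3 brought a 3-(trifluoromethyl)phenyl and went up modestly. Going by the values given here, the 3-bromophenyl of compound 4 has no measured counterpart, so the expected direction is uncertain, and the expected step is small, a number 3.5 percentage points higher from compound 1 to compound 4 (within the scatter). Compound 4 is therefore estimated at 82%, within a range from 70% to 92%.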

Compound 4, percent growth inhibition at one concentration: 92.2%
Beside the measured number, compound 4's estimate is 10.2 percentage points below it; the whole stated range lies below it.
By their numbers in this assay, from the lowest: compounds 2 and 1 (each within the scatter of the next); then compounds 3 and 4 (each within the scatter of the next).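

In this assay the 3-bromophenyl on the amide-type nitrogen gives a number 13.7 percentage points higher from compound 1 to compound 4 (beyond the scatter) and so joins the 3-(trifluoromethyl)phenyl of compound 3 in rising beyond the scatter from the 4-methoxyphenyl, while the 3-cyanophenyl of compound 2 goes against this. Bromo and trifluoromethyl cannot be told apart at this place, as a number 3 percentage points higher from compound 3 to compound 4 (within the scatter) shows, yet bromo separates from cyano with a number 18.6 percentage points higher from compound 2 to compound 4 (beyond the scatter) and the ring substituent therefore matters here. Nothing measured here gives a reason for these differences.

Each swap from compound 1 changes both the substituent and where it sits on the ring, so a 4-bromophenyl or a 3-methoxyphenyl would be needed to separate the two. As far as these compounds go, how a 3-aminophenyl or a 3-carboxyphenyl would behave on this nitrogen also stays open.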